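The source may hold more compounds than are shown below. What is called first, only, known or untested is meant among the compounds shown, and "the series" means these compounds.

Compound 2 `COc1ncnc2c1c(-c1ccoc1)cn2[C@@H]1O[C@H](CO)[C@@H](O)[C@H]1O` is the reference point of this account. In a functional assay on A549 cells (Homo sapiens), read by MTT assay, with a stated time of 72 h (on this read-out lower numbers stand for stronger inhibition and higher numbers for weaker inhibition), compound 2 gives 1160 nM, the lowest of the two numbers recorded there, with compound 1 `COc1ncnc2c1c(-c1ccsc1)cn2[C@@H]1O[C@H](CO)[C@@H](O)[C@H]1O` as its nearest neighbour. In this assay compound 1 gives 5170 nM, and the change a 4.5-fold lower number from compound 1 to compound 2 (0.65 log units; beyond the scatter) follows from furan-3-yl in place of thiophen-3-yl on an aromatic carbon. A third analogue, compound 3 `CN(C)c1ncnc2c1c(-c1ccoc1)cn2[C@@H]1O[C@H](CO)[C@@H](O)[C@H]1O`, carries dimethylamino in place of methoxy on an aromatic carbon. In this assay compound 3 reaches only the limit of the assay, > 20000 nM, and not a number. That step, an at least 17-fold higher number from compound 2 to compound 3 (1.23 log units; beyond the scatter), is the larger of the two measured moves.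

The step now followed leads from compound 2 to compound 4 `COc1ncnc2c1c(-c1cccs1)cn2[C@@H]1O[C@H](CO)[C@@H](O)[C@H]1O`, whose difference from compound 2 is thiophen-2-yl in place of furan-3-yl on an aromatic carbon. For the measured compounds named here, only the step from compound 1 to compound 2 bears on it, and in the opposite sense, since there a furan replaced a thiophene and the number fell by a 4.5-fold lower number from compound 1 to compound 2 (0.65 log units; beyond the scatter); the attachment point of the thiophene differs, so the comparison is loose. A modest rise in the number is therefore expected for compound 4, about a 3.0-fold higher number from compound 2 to compound 4 (0.48 log units; beyond the scatter). The estimate for compound 4 in this assay is 3500 nM, within a range from 1200 nM to 12000 nM.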

Compound 4, half-maximal inhibitory concentration: 4850 nM
Compound 4: middle estimate off by 1.4-fold (0.14 log units), on the low side, and the stated range covers the measured number.
By their numbers in this assay, from the lowest: compound 2; then compounds 4 and 1 (each within the scatter of the next). At a limit, above all of these: compound 3.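

In this assay the exchange of furan-3-yl for thiophen-2-yl gives a 4.2-fold higher number from compound 2 to compound 4 (0.62 log units; beyond the scatter), so the gap first seen with thiophen-3-yl in compound 1 also appears when the sulfur ring is attached through its other carbon. The two thiophenes can now be compared directly, and the step shows a 1.1-fold lower number from compound 1 to compound 4 (0.03 log units; within the scatter), which means that moving the attachment point of the thiophene on this aromatic carbon of the core has no effect that can be told from the scatter. The earlier compounds shown here could not separate the kind of ring from its attachment point, whereas these three methoxy compounds place compound 2 on its own, with compound 1 and compound 4 together at a higher level of the read-out.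

On these data alone, how a furan-2-yl, a phenyl or a pyridin-3-yl group would read at this carbon remains open, so it cannot be said whether furan-3-yl is unusual or the two thiophenes are, and whether the attachment point matters for a furan is equally unsettled. The data shown offer nothing that bears on the reason for the difference between furan-3-yl and the thiophenes.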